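Deacetylase series: nitro-chromene amides with varied linker end

The source may report more compounds than this note shows. Statements on the series, on what has been measured and on what is new or still open speak of the compounds shown alone.

Measured in an assay on isolated protein for inhibition of protein deacetylase HDAC6 (Homo sapiens), read by fluorescence, with stated times of 10 min and 30 min, tested at 10 uM; on this read-out lower numbers stand for less inhibition and higher numbers for more inhibition at the one concentration tested (going by the name of the read-out):
compound 1 `CCOc1cc(NC(=O)CCCCCNC(=O)CCCc2ccccc2)cc2c1OCC([N+](=O)[O-])=C2`: 43%
compound 2 `CCOc1cc(NC(=O)CCCCCCC(=O)Nc2cc(-c3ccc(C)s3)ccc2N)cc2c1OCC([N+](=O)[O-])=C2`: 19%

Compound 2 stands lowest of the two numbers in this assay; compound 1 sits higher by a gap beyond the scatter of repeated runs. Only these two values are known, so no pattern is drawn from them.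

Compound 3 `CCOc1cc(NC(=O)CCCCCCC(=O)Nc2ccccc2N)cc2c1OCC([N+](=O)[O-])=C2` is the next analogue and has not yet been measured in this assay. Against compound 2 the change is hydrogen in place of 5-methylthiophen-2-yl on an aromatic carbon. For the measured compounds named here, no measured pair shows a step of this kind, so the expectation rests on compound 2 alone, and compound 2 with 19% already leaves little room. The expected step of a number 4 percentage points lower from compound 2 to compound 3 (within the scatter) is therefore estimated, a small change that may lie within the scatter, if anything downward. On that basis compound 3 is expected to give about 15% in this assay, with a range from 0% to 35%.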

Compound 3, a percentage reported as inhibition, at one concentration (the size of the read-out at that concentration, not a potency): 52%
Compound 3: the middle estimate sits 37 percentage points below what was measured, and the stated range ends below it.
By their numbers in this assay, from the lowest: compound 2; then compounds 1 and 3 (each within the scatter of the next).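

In this assay, hydrogen in place of 5-methylthiophen-2-yl on the aromatic carbon gives a number 33 percentage points higher from compound 2 to compound 3 (beyond the scatter), so at this position, meta to a large group and para to an amino group, the number depends strongly on the substituent. ((2-Aminophenyl)carbamoyl)methyl in place of ((3-phenylpropyl)carbonyl)amino on the saturated chain gives a number 9 percentage points higher from compound 1 to compound 3 (within the scatter), so these two chain ends are not told apart in this read-out. Nothing available bears on the reason for the step at the aromatic carbon.

Still open, from the compounds shown here alone, is where a methyl group, a fluorine atom or a phenyl group on that aromatic carbon would fall relative to hydrogen and 5-methylthiophen-2-yl. Also open, going by these compounds, is how a hydroxamic acid at the chain end, or a longer chain, would read.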